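Indole series: benzyloxy to ethyl on the fused ring

The source may hold more compounds than are shown below. What is called first, only, known or untested is meant among the compounds shown, and "the series" means these compounds.

Of the compounds shown here, two carry a measured value so far. Compound 1 `CN1CCCN(CCn2ccc3cc(Br)ccc32)CC1` gives 88 nM in an assay on HEK293 cells for binding affinity to 5-hydroxytryptamine receptor 7 (Homo sapiens), read by radioligand binding; on this read-out lower numbers stand for stronger inhibition and higher numbers for weaker inhibition. Compound 2 `CN1CCCN(CCn2ccc3ccc(OCc4ccccc4)cc32)CC1` gives 182 nM in this assay, the highest of the two numbers; the gap to compound 1 is beyond the usual scatter, so compound 2 is the weaker binder of the pair. Compound 3 `CCc1ccc2ccn(CCN3CCCN(C)CC3)c2c1` is not yet measured. It differs from compound 2 in one place: ethyl in place of benzyloxy on an aromatic carbon. Going by the values given here, no step between measured compounds matches this change, so its size can only be estimated. Because compound 2 gives 182 nM and the remaining group is an ethyl rather than a benzyloxy, a modest move to a lower number is expected, with the step from a 1.4-fold lower number from compound 2 to compound 3 (0.15 log units; within the scatter) estimated to lie near the edge of the scatter. Compound 3 is therefore expected to give about 130 nM, within a range of 45 nM to 380 nM.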

Compound 3, inhibition constant: 166 nM
Beside the measured number, compound 3's estimate is 1.3-fold (0.11 log units) below it; measured number inside the range.
By their numbers in this assay, from the lowest: compounds 1, 3 and 2 (each within the scatter of the next, the first and the last beyond it).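

Replacing benzyloxy with ethyl on this aromatic carbon, meta to a fused ring and para to a fused ring, removes a six-membered aromatic ring of carbon only and a hydrogen-bond acceptor. In this assay this change gives a 1.1-fold lower number from compound 2 to compound 3 (0.04 log units; within the scatter) and so does not separate the two groups, which shows that at this position the read-out can stay within the scatter across this change in substituent. No measured data shown bear on the reason for this result.

On these data alone, whether the same holds for a hydroxyl, an amine or a carboxylic acid on this carbon remains open. As far as these compounds go, it is also open whether ethyl and benzyloxy would stay within the scatter of each other on another carbon of the shared core.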